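Acetyl to dimethylamino on the pendant phenyl ring

A few compounds are considered here, and "the series" means these few. Any claim that something is new, unique, unknown or untested is made for them only; others in the source may bear on it.

Measured so far:
compound 1 `COc1cc(C)cc(-c2c(-c3ccnc(-c4ccc(C(C)=O)cc4)c3)cnn2CC#N)c1`, 7%
compound 2 `COc1cc(C)cc(-c2nn(CC#N)cc2-c2ccc(-c3cccc(C(C)=O)c3)nc2)c1`, 19%

Both compounds were tested in a functional assay on MOLT-4 cells (Homo sapiens) for cytotoxicity, read by sulforhodamine B assay, with a stated time of 48 h, tested at 1 uM; a higher number here means a weaker effect of the compound at the concentration tested, a lower number a stronger effect. Compound 1 gives 7%, the lowest of the two numbers, and so the strongest effect at the concentration tested. Compound 2 gives 19%; its number lies higher than that of compound 1 by a margin beyond the scatter. Among the measured compounds shown here, no step between compounds differing in one place has been measured, so no change of a single group has a known size.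

Compound 3 `COc1cc(C)cc(-c2c(-c3ccnc(-c4ccc(N(C)C)cc4)c3)cnn2CC#N)c1` has not yet been measured. It differs from compound 1 in one place: dimethylamino in place of acetyl on an aromatic carbon. Since nothing measured speaks to this change, the expectation rests on compound 1 alone, whose value 7% leaves little room for a lower number. A step of modest size toward a higher number, or none beyond the scatter, is expected from compound 1 to compound 3 in this assay, namely a number 13 percentage points higher from compound 1 to compound 3 (beyond the scatter). For compound 3 the estimate is 20%, with a range from 4% to 55%.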

Compound 3, a percentage reported as activity, at one concentration (the size of the read-out at that concentration, not a potency): -2%
For compound 3 the middle estimate is 22 percentage points above the measured one; the measured number lies below the stated range.
By their numbers in this assay, from the lowest: compounds 3 and 1 (each within the scatter of the next); then compound 2.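

In this assay, among the compounds shown here, the exchange of 4-acetylphenyl for 4-(dimethylamino)phenyl gives the first single-place step, a number 9 percentage points lower from compound 1 to compound 3 (within the scatter), so the two groups cannot be told apart at this aromatic carbon at the concentration tested. The acetyl group, with its carbonyl, is therefore not required here for the effect seen with compound 1, and dimethylamino serves as a workable replacement on this core. No measurement in hand bears on why the two groups read alike.

On these data alone, whether this tolerance extends to other groups at the same carbon, such as a carboxylic acid, a primary amine or a longer chain ending in morpholine, remains open, and a single concentration cannot show whether compound 1 and compound 3 would separate in potency. As far as these compounds go, compound 2, at 19%, differs from compound 1 in more than one place, so whether the dimethylamino exchange would behave the same way on the core of compound 2 also remains open.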